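The source may hold more compounds than are shown below. What is called first, only, known or untested is meant among the compounds shown, and "the series" means these compounds.

Measured so far in a physicochemical assay for acid dissociation:
Compound 1 `COc1ccc(Oc2ccc3c(NCCCNCc4cc(F)ccc4OC)ccnc3c2)cc1` — 9.28
Compound 2 `c1ccc(-c2ccc3c(NCCCNCc4ccco4)ccnc3c2)cc1` — 9.47
Compound 3 `COc1cccc(CNCCCNc2ccnc3cc(-c4ccccc4)ccc23)c1O` — 9.47

Compound 2 and compound 3 share the same number at the digits printed, and together they are the highest of the three; compound 1 sits lower by a gap that falls within the scatter, so no order among the three is established. Among the compounds with values here, the one step in this set, no change at the digits printed from compound 2 to compound 3 (within the scatter), changes the group on the saturated chain carbon bound to an amine nitrogen and leaves the reading unchanged within the scatter.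

Compound 4 `COc1ccc(-c2ccc3c(NCCCNCc4ccco4)ccnc3c2)cc1` differs from compound 2 elsewhere: methoxy in place of hydrogen on an aromatic carbon, the new group sitting on an aromatic carbon of a six-membered aromatic ring of carbon only, para to a large group. Within the data shown here, no measured step touches that ring, so the step from compound 2 to compound 3 bears on it only as a sign that changes away from the chain have so far left this assay untouched. The step of no change at the digits printed from compound 2 to compound 4 (within the scatter) is therefore expected to stay within the scatter. For compound 4 the estimate is 9.47, with a range from 9.2 to 9.75.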

Compound 4, acid dissociation constant: 9.47
Compound 4: middle estimate and measured number agree at the digits printed, within the range that was stated.
By their numbers in this assay, from the lowest: compounds 1, 2, 3 and 4 (each within the scatter of the next).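

Turning phenyl into 4-methoxyphenyl gives the first reading for a change at this position, and in this assay it produces no change at the digits printed from compound 2 to compound 4 (within the scatter). The earlier step concerned a group on a saturated chain carbon, whereas this one shows that a group of 2 heavy atoms, with 1 hydrogen-bond acceptor, can enter on this aromatic carbon, para to a large group, without moving the number beyond the scatter. Nothing at hand explains this outcome.

The compounds shown leave open whether an amine or a carboxylic acid in the same place would also keep the number within the scatter. They also do not show which part of the molecule gives up the proton.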